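The source may report more compounds than this note shows. Statements on the series, on what has been measured and on what is new or still open speak of the compounds shown alone.

Compound 3 `FCCCOc1cccc(-c2cn([C@H]3CN4CCC3CC4)nn2)c1` gives 1630 nM in an assay on HEK293 cells for displacement of a labelled ligand from Neuronal acetylcholine receptor; alpha3/beta4 (Homo sapiens), read by scintillation counting, with a stated time of 120 min (on this read-out lower numbers stand for stronger inhibition and higher numbers for weaker inhibition), the highest number among the three compounds measured. Going by the values given here, its nearest neighbour is compound 2 `FCCOc1cccc(-c2cn([C@H]3CN4CCC3CC4)nn2)c1`, which gives 558 nM; the single measured step, a 2.9-fold higher number from compound 2 to compound 3 (0.47 log units; beyond the scatter), comes from lengthening the fluorinated chain. Compound 1 `c1ccc(COc2cccc(-c3cn(C4CN5CCC4CC5)nn3)c2)cc1` carries a benzyloxy group instead and gives 7.57 nM, far lower than compound 3. Compound 4 `c1ccc(COc2cccc(-c3cn([C@H]4CN5CCC4CC5)nn3)c2)cc1` differs from compound 3 by phenyl in place of 2-fluoroethyl on a saturated chain carbon bound to an oxygen on an aromatic ring, so that 3-fluoropropoxy becomes benzyloxy. Among the compounds with values here, no measured step covers exactly this swap; the measured step bears on it only weakly. Because compound 1 with the same benzyloxy group gives 7.57 nM, compound 4 is expected to show a large drop, a 270-fold lower number from compound 3 to compound 4 (2.43 log units; beyond the scatter). The estimate for compound 4 is 6 nM, within 2 nM to 20 nM.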

Compound 4, inhibition constant: 631 nM
Estimate against measurement, compound 4: 110-fold (2.02 log units) below, and the stated range ends below it.
By their numbers in this assay, from the lowest: compound 1; then compounds 2 and 4 (each within the scatter of the next); then compound 3.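

Benzyloxy in place of 3-fluoropropoxy gives only a 2.6-fold lower number from compound 3 to compound 4 (0.41 log units; beyond the scatter), and the comparison with the shorter fluorinated chain gives a 1.1-fold higher number from compound 2 to compound 4 (0.05 log units; within the scatter), so with the configuration of compound 4 this group alone does not bring the low number of compound 1. The large step, an 83-fold higher number from compound 1 to compound 4 (1.92 log units; beyond the scatter), involves no change in atoms or bonds, and it points to the stereocentre rather than the chain: the fact that one of compounds 1 and 4 is drawn with a defined configuration and the other without, at the place where they differ

Still open, as far as these compounds go, is which configuration at that ring carbon is present in compound 1, and how the opposite configuration would read with each fluorinated chain. Also open, from the compounds shown here alone, is how an amine or a carboxylic acid in place of benzyloxy would read.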